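The source may report more compounds than this note shows. Statements on the series, on what has been measured and on what is new or still open speak of the compounds shown alone.

Measured in a functional assay on HeLa cells (Homo sapiens) for cytotoxicity, read by MTT assay, with a stated time of 48 h; a higher number here means a weaker inhibitor, a lower number a stronger inhibitor:
compound 1 `Cc1nc2c3ccccc3ccc2c2nc3c(ccc4ccccc43)c(-c3nccnc3N)c12` gives 1210 nM
compound 2 `Cc1nc2c3ccccc3ccc2c2nc3c(ccc4ccccc43)c(-c3ccccc3N)c12` gives 16200 nM
compound 3 `Cc1nc2c3ccccc3ccc2c2nc3c(ccc4ccccc43)c(-c3ccccc3S)c12` gives 3190 nM

Compound 3 holds the second-highest number of the three in this assay; the nearer step is a 2.6-fold higher number from compound 1 to compound 3 (0.42 log units; beyond the scatter) and the wider is a 5.1-fold lower number from compound 2 to compound 3 (0.71 log units; beyond the scatter). Compound 4 `Cc1nc2c3ccccc3ccc2c2nc3c(ccc4ccccc43)c(-c3ccc(O)cc3)c12` differs from compound 3 by 4-hydroxyphenyl in place of 2-sulfanylphenyl on an aromatic carbon. Among the compounds with values here, no measured step exchanges exactly these two groups. Within the data shown here, the steps that bear on the change are the modest 5.1-fold lower number from compound 2 to compound 3 (0.71 log units; beyond the scatter), a swap of substituent on the pendant phenyl, and the large 13-fold higher number from compound 1 to compound 2 (1.13 log units; beyond the scatter). A step of modest size in this assay is therefore expected, direction uncertain, a higher number somewhat more likely. Compound 4 is estimated at 4500 nM (range 1500 nM to 14000 nM), an expected 1.4-fold higher number from compound 3 to compound 4 (0.15 log units; within the scatter).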

Compound 4, half-maximal inhibitory concentration: 4630 nM
The estimate for compound 4 lay 1.0-fold (0.01 log units) below the measured number; measured number inside the range.
By their numbers in this assay, from the lowest: compound 1; then compounds 3 and 4 (each within the scatter of the next); then compound 2.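

In this assay, 4-hydroxyphenyl on this aromatic carbon, opposite the ring nitrogen, reads level with 2-sulfanylphenyl (a 1.5-fold higher number from compound 3 to compound 4 (0.16 log units; within the scatter)). Both steps to the remaining groups lie beyond the scatter (a 3.5-fold lower number from compound 2 to compound 4 (0.54 log units; beyond the scatter); a 3.8-fold higher number from compound 1 to compound 4 (0.58 log units; beyond the scatter)), so compound 4 joins compound 3 in the middle of the series, with 3-aminopyrazin-2-yl still giving the lowest number and 2-aminophenyl the highest. No evidence bears on the cause of these differences.

Ring position and substituent change together between compound 3 and compound 4, so their contributions cannot be separated. A 2-hydroxyphenyl or 4-aminophenyl group would separate them.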